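Aryl swap on the hydrazone carbon: outlook for compound 3

The compounds below may be only part of what the source reports. "The series", "measured", "known", "first", "only" and "open" are said of these compounds alone.

Among the measured compounds shown here, compound 2 `CN(C)CCn1cnnc1-c1cc(Oc2ccc(NC(=O)N/N=C/c3ccccc3O[N+](=O)[O-])cc2F)ccn1` gives the only measured number, 1200 nM in a functional assay on A549 cells (Homo sapiens) for cytotoxicity, read by MTT assay, with a stated time of 72 h; a higher number here means a weaker inhibitor, a lower number a stronger inhibitor. Compound 1 `CN(C)CCn1cnnc1-c1cc(Oc2ccc(NC(=O)N/N=C/c3ccc(O)c(O)c3)cc2F)ccn1` is known in this assay only as a limit, > 100000 nM. For the measured compounds named here, the single measured step, an at least 83-fold lower number from compound 1 to compound 2 (1.92 log units; beyond the scatter), changed the aryl group on the carbon with a double bond to nitrogen, the same place altered in compound 3 `COc1ccc(/C=N/NC(=O)Nc2ccc(Oc3ccnc(-c4nncn4CCN(C)C)c3)c(F)c2)c(OC)c1OC`: 2,3,4-trimethoxyphenyl in place of 2-(nitrooxy)phenyl on a carbon with a double bond to nitrogen. That step shows the aryl group here can shift the number strongly, but it says nothing of 2,3,4-trimethoxyphenyl. Compound 3 is expected to land near compound 2, a step of a 2.5-fold higher number from compound 2 to compound 3 (0.40 log units; beyond the scatter) with wide uncertainty. The estimate for compound 3 is 3000 nM, from 500 nM to 30000 nM.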

Compound 3, half-maximal inhibitory concentration: 6680 nM
Estimate against measurement, compound 3: 2.2-fold (0.35 log units) below, within the range that was stated.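

On the carbon with a double bond to nitrogen, two different aryl groups now give measured numbers in this assay, and the exchange between them gives a 5.6-fold higher number from compound 2 to compound 3 (0.75 log units; beyond the scatter). The gain over 3,4-dihydroxyphenyl is therefore not confined to 2-(nitrooxy)phenyl, since 2,3,4-trimethoxyphenyl also gives an at least 14-fold lower number from compound 1 to compound 3 (1.17 log units; beyond the scatter). The true size of that step stays unknown, as compound 1 is recorded only as a limit and not a number: the limit of > 100000 nM in this assay, at which 1 of the 3 values shown sits.

Still open, on these data alone, is how an unsubstituted phenyl, a phenyl with a single methoxy group or an aminophenyl would read at this position.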